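A few compounds are considered here, and "the series" means these few. Any claim that something is new, unique, unknown or untested is made for them only; others in the source may bear on it.

Compound 1 `CCCCCCCCOc1nc(N)nc2c1ncn2/C=C1/CC1(CO)CO`: > 20000 nM (a limit)
Compound 2 `Nc1nc(NC2CCCC2)c2ncn(/C=C3/CC3(CO)CO)c2n1`: 71700 nM

Within the data shown here, in an ADME assay on BCBL1 cells (Homo sapiens) for cytotoxicity, with a stated time of 7 days (on this read-out lower numbers stand for higher toxicity in this test and higher numbers for lower toxicity in this test), compound 2 gives 71700 nM, the only actual number so far. Compound 3 `CCCCCOc1nc(N)nc2c1ncn2/C=C1/CC1(CO)CO` carries pentyloxy in place of cyclopentylamino on an aromatic carbon. Among the measured compounds shown here, the one measured step that changes this group is a step that the limit leaves unreadable from compound 1 to compound 2. That step starts from a limit: the limit of > 20000 nM in this assay, at which 1 of the 2 values shown sits. It therefore offers no size or direction to carry over, so no change beyond the scatter is expected, and the estimated 1.4-fold lower number from compound 2 to compound 3 (0.16 log units; within the scatter) is small. For compound 3 the expected value is 50000 nM, with an estimated range of 15000 nM to 150000 nM.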

Compound 3, half-maximal cytotoxic concentration: > 20000 nM
Compound 3: no number, only a limit; the forecaster's own chance of this, stated with the estimate: 50%; the middle value does not contradict the limit.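

Compound 3 gives > 20000 nM, which is a limit and not a number, so its steps from compound 1 and compound 2 cannot be read. The compounds shown leave open whether pentyloxy or cyclopentylamino on the shared core gives the higher number in this assay.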